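Stereochemical Variants of a Hydroxy Amide Ester

A few compounds are considered here, and "the series" means these few. Any claim that something is new, unique, unknown or untested is made for them only; others in the source may bear on it.

Measured so far:
compound 1 `CCOC(=O)/C=C/NC(=O)[C@H](O)C(C)(C)CO`: -5%
compound 2 `CCOC(=O)/C=C\NC(=O)[C@H](O)C(C)(C)CO`: -6%

In an ADME assay on HEK293 cells (Homo sapiens) for inhibition, read by CellTiter-Glo, with a stated time of 96 h, tested at 100 uM (a higher number here means more inhibition at the concentration tested (going by the name of the read-out), a lower number less inhibition), compound 1 gives -5% and compound 2 gives -6%. Compound 2 has the lowest of the two numbers; the nearest is compound 1, and the step from one to the other is a number 1 percentage points lower from compound 1 to compound 2 (within the scatter). That step rests on (the fact that compounds 1 and 2 differ only in the configuration as drawn), so a change of the drawn double bond alone leaves the read-out where it was.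

Compound 3 `CCOC(=O)/C=C/NC(=O)[C@@H](O)C(C)(C)CO` is the next compound to be measured in this assay. Relative to compound 2 the change is the two compounds have the same atoms and bonds and differ only in configuration as drawn: 2 of 2 stereo elements differ; a stereocentre at a saturated chain carbon is drawn R in compound 2 and S in compound 3; a double bond is drawn Z in compound 2 and E in compound 3. Among the measured compounds shown here, the measured step from compound 1 to compound 2 covers only the double-bond part of this change; no measured pair shows what inverting the stereocentre does. Given that both measured numbers sit near zero and the one available step is within the scatter, the expected step in this assay is a number 1 percentage points higher from compound 2 to compound 3 (within the scatter), meaning none beyond the scatter. Compound 3 is therefore estimated at -5% in this assay, with an expected range from -20% to 10%.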

Compound 3, a percentage reported as inhibition, at one concentration (the size of the read-out at that concentration, not a potency): -9%
For compound 3 the middle estimate is 4 percentage points above the measured one, and the stated range covers the measured number.
By their numbers in this assay, from the lowest: compounds 3, 2 and 1 (each within the scatter of the next).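

In this assay the stereocentre at the saturated chain carbon now has a measured pair of its own: with the double bond drawn E in both compounds, going from R to S gives a number 4 percentage points lower from compound 1 to compound 3 (within the scatter) and so does not move the read-out beyond the scatter. Changing both stereo elements together, the stereocentre from R to S and the double bond from Z to E, gives a number 3 percentage points lower from compound 2 to compound 3 (within the scatter) and likewise stays inside the scatter, so neither the single inversion nor the double change separates these compounds. The reading for the stereocentre alone rests on a pair in which nothing else is altered: the fact that compounds 1 and 3 differ only in the configuration as drawn.

The compounds shown leave open the fourth combination of these two stereo elements, the Z double bond with the S stereocentre, and they cover only configuration, since all three share the same atoms and bonds. From the compounds shown here alone, whether a different group would separate itself from these three in this assay, such as a carboxylic acid in place of the ethyl ester or an amine in place of the hydroxyl, also remains open.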